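Removing the chloro from compound 2: an expected flat step

The source may report more compounds than this note shows. Statements on the series, on what has been measured and on what is new or still open speak of the compounds shown alone.

Measured so far:
compound 1 `COc1ccc(-c2nc(SCC(=O)c3sc(-c4ccccc4)nc3C)[nH]c(=O)c2C#N)cc1` — 52.1%
compound 2 `Cc1nc(-c2ccccc2)sc1C(=O)CSc1nc(-c2cccc(Cl)c2)c(C#N)c(=O)[nH]1` — 50.6%

In a functional assay on U-87MG ATCC cells for antiproliferative activity against U-87 MG (Homo sapiens), read by MTT assay, with a stated time of 48 h, tested at 50 uM (on this read-out higher numbers stand for a weaker effect at the one concentration tested and lower numbers for a stronger effect), compound 1 gives 52.1%, and compound 2 gives 50.6%. Among the compounds with values here, the only step measured so far, a number 1.5 percentage points lower from compound 1 to compound 2 (within the scatter), places the two numbers within the scatter of each other, so compound 2 stands level with compound 1 and neither can be called the stronger of the pair.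

Compound 3 `Cc1nc(-c2ccccc2)sc1C(=O)CSc1nc(-c2ccccc2)c(C#N)c(=O)[nH]1` arises from compound 2 by one change: hydrogen in place of chloro on an aromatic carbon. Within the data shown here, no measured step concerns this exact change; the one step available, from a 4-methoxyphenyl to a 3-chlorophenyl on the same aromatic carbon, was flat. Since that swap of one aryl group for another left the read-out unmoved, the loss of a single chloro is expected to do likewise, giving a step of a number 1.4 percentage points higher from compound 2 to compound 3 (within the scatter), none beyond the scatter. On that basis compound 3 is estimated at 52%, between 40% and 65%.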

Compound 3, a percentage reported as activity, at one concentration (the size of the read-out at that concentration, not a potency): 77.5%
Compound 3: the middle estimate sits 25.5 percentage points below what was measured, outside the stated range (above it).
By their numbers in this assay, from the lowest: compounds 2 and 1 (each within the scatter of the next); then compound 3.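

Losing the ring substituent is not neutral in this assay: the chloro-to-hydrogen change gives a number 26.9 percentage points higher from compound 2 to compound 3 (beyond the scatter) and the methoxy-to-hydrogen change gives a number 25.4 percentage points higher from compound 1 to compound 3 (beyond the scatter), so the bare phenyl of compound 3 has the weaker effect at the one concentration tested. The flat step between the 4-methoxyphenyl of compound 1 and the 3-chlorophenyl of compound 2 therefore did not show that this aromatic ring tolerates any change, since two different substituted rings stand level while the unsubstituted ring does not. Nothing in the data available here bears on why hydrogen differs from these two groups.

The compounds shown leave open whether an amine or a carboxylic acid on this ring would stand with compound 1 and compound 2 or with compound 3. They also leave open how much the place of a substituent counts, as the chloro and methoxy groups sit at different places and no single group is shown at both.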